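Swapping Bromo for Benzyloxy: Expected Cytotoxicity of Compound 4

The source may report more compounds than this note shows. Statements on the series, on what has been measured and on what is new or still open speak of the compounds shown alone.

Compound 1 `Cc1cc(O)c(C(=O)/C=C/c2ccc(Cl)cc2)c(-c2ccccc2)c1C(=O)/C=C/c1ccc(Cl)cc1`: 30000 nM
Compound 2 `Cc1cc(O)c(C(=O)/C=C/c2ccc3ccccc3c2)c(-c2ccccc2)c1C(=O)/C=C/c1ccc2ccccc2c1`: "not active" (no number reported)
Compound 3 `Cc1cc(O)c(C(=O)/C=C/c2ccc(Cl)cc2)c(-c2ccc(Br)cc2)c1C(=O)/C=C/c1ccc(Cl)cc1`: 32000 nM

Of the compounds shown here, three sharing one core have been tested in a functional assay on HeLa cells (Homo sapiens) for cytotoxicity, read by MTT assay, with a stated time of 24 h; a lower number here means a stronger inhibitor, a higher number a weaker inhibitor. Compound 1 gives 30000 nM in this assay, and compound 3 gives 32000 nM. Compound 2 is reported in this assay as "not active" (no number reported), with no number attached. Compound 3 therefore stands highest of the two numbers, yet its nearest neighbour, compound 1, lies within the scatter: the step of a 1.1-fold higher number from compound 1 to compound 3 (0.03 log units; within the scatter) is too small to count as a real change.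

Compound 4 `Cc1cc(O)c(C(=O)/C=C/c2ccc(Cl)cc2)c(-c2ccc(OCc3ccccc3)cc2)c1C(=O)/C=C/c1ccc(Cl)cc1` has not yet been measured. It differs from compound 3 by benzyloxy in place of bromo on an aromatic carbon. Within the data shown here, the only measured step at this position, a 1.1-fold higher number from compound 1 to compound 3 (0.03 log units; within the scatter), bears on it indirectly and was within the scatter. No step with a benzyloxy group exists among these compounds, so the expectation rests on that single neighbouring step alone. Compound 4 is therefore expected to show a step of no change at the digits printed from compound 3 to compound 4 (within the scatter), no larger than the scatter. The estimate for compound 4 in this assay is 32000 nM, expected to fall between 12000 nM and 90000 nM.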

Compound 4, half-maximal inhibitory concentration: "not active" (no number reported)
No number was reported for compound 4; the estimate stays without a comparison.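

In this assay, among these compounds, compound 4 is reported as "not active" with no number, so no step from compound 3 to compound 4 can be read. No evidence shown here accounts for this result. The compounds shown leave open how benzyloxy compares numerically with bromo at this position.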